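The compounds below may be only part of what the source reports. "The series", "measured", "known", "first", "only" and "open" are said of these compounds alone.

In a functional assay on HCT-116 cells (Homo sapiens) for antiproliferative activity, read by sulforhodamine B assay, with a stated time of 72 h (a lower number here means a stronger inhibitor, a higher number a weaker inhibitor), the measured compounds read:

Compound 1 `COc1ncc(-c2ccc3c(c2)N(CCCn2ccccc2=O)C(=O)CO3)cc1NS(=O)(=O)c1ccc(F)cc1F` gives 4230 nM
Compound 2 `CCCCS(=O)(=O)Nc1cc(-c2ccc3c(c2)N(CCCN(CC)CC)C(=O)CO3)cnc1OC` gives 14600 nM
Compound 3 `CCCCS(=O)(=O)Nc1cc(-c2ccc3c(c2)N(CCCN(C)C)C(=O)CO3)cnc1OC` gives 8430 nM

Compound 2 stands level with compound 3, within the scatter, while the number for compound 1 is lower than that of compound 2 by more than the scatter. Compound 4 `CCCCS(=O)(=O)Nc1cc(-c2ccc3c(c2)N(CCC(=O)N2CCOCC2)C(=O)CO3)cnc1OC` is still unmeasured. Its side chain differs from that of compound 2 as follows: (morpholin-4-yl)carbonyl in place of (diethylamino)methyl on a saturated chain carbon, two bonds along the chain from an amide-type nitrogen in a ring. In words, (morpholin-4-yl)carbonyl takes the place of (diethylamino)methyl on a saturated chain carbon, two bonds along the chain from an amide-type nitrogen in a ring.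

Going by the values given here, only one measured step touches this chain (a 1.7-fold lower number from compound 2 to compound 3 (0.24 log units; within the scatter)), and it stays within the scatter. That step only swaps dimethylamino for diethylamino, a smaller edit than this one, so it is a weak guide. Compound 1 also differs from compound 2 elsewhere and offers no clean comparison. No step beyond the scatter is therefore expected in this assay, with a slight lean towards a lower number. The estimated step is small (a 1.6-fold lower number from compound 2 to compound 4 (0.21 log units; within the scatter)). For compound 4 the expected value is about 9000 nM, with an estimated range from 3500 nM to 23000 nM.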

Compound 4, half-maximal inhibitory concentration: 23500 nM
For compound 4 the middle estimate is 2.6-fold (0.42 log units) below the measured one; the measured number lies above the stated range.
By their numbers in this assay, from the lowest: compounds 1, 3, 2 and 4 (each within the scatter of the next, the first and the last beyond it).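

In this assay, (morpholin-4-yl)carbonyl in place of (diethylamino)methyl gives a 1.6-fold higher number from compound 2 to compound 4 (0.21 log units; within the scatter), so even this larger change on the saturated chain carbon, which brings in a ring and a carbonyl, leaves compound 4 level with compound 2, while the same kind of replacement measured against the smaller (dimethylamino)methyl gives a 2.8-fold higher number from compound 3 to compound 4 (0.45 log units; beyond the scatter), a modest step and the first on this chain to pass the scatter. Among these three compounds, which differ only in the end of this chain, the single step beyond the scatter runs towards a higher number, meaning a weaker inhibitor, and neither step away from compound 2 lowers the number beyond the scatter. No measurement available here accounts for these differences.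

The carbonyl and the morpholine ring enter together in compound 4, so the compounds shown leave open which of the two goes with the higher number, a question that a plain 3-(morpholin-4-yl)propyl chain or a 2-((piperidin-1-yl)carbonyl)ethyl chain could address. Also open, as far as these compounds go, is how a carboxylic acid or a longer chain at this place would read in this assay.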